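The compounds below may be only part of what the source reports. "The series", "measured", "known", "first", "only" and "open" are said of these compounds alone.

The measured compounds, all tested in a functional assay on HCT-116 cells (Homo sapiens) for inhibition, read by sulforhodamine B assay, with a stated time of 72 h; a lower number here means a stronger inhibitor, a higher number a weaker inhibitor:

Compound 1, `COc1ccc(C(=O)/C=C/c2cn(-c3ccccc3)nc2-c2ccsc2)c(OC)c1OC`: compound 1 gives 5800 nM
Compound 2, `COc1ccc(C(=O)/C=C/c2cn(-c3ccccc3)nc2-c2ccsc2)cc1OC`: compound 2 gives 1600 nM
Compound 3, `COc1ccc(C(=O)/C=C/c2cn(-c3ccccc3)nc2-c2ccsc2)c(OC)c1`: compound 3 gives 2200 nM

Compound 2 holds the lowest number of the three. Its distance from compound 1 is real, as a 3.6-fold lower number from compound 1 to compound 2 (0.56 log units; beyond the scatter) shows, whereas a 1.4-fold higher number from compound 2 to compound 3 (0.14 log units; within the scatter) stays within the scatter, so compounds 2 and 3 cannot be ranked against each other.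

Compound 4, `COc1ccc(C(=O)/C=C/c2cn(-c3ccccc3)nc2-c2ccncc2)cc1OC`, departs from compound 2 by pyridin-4-yl in place of thiophen-3-yl on an aromatic carbon. Going by the values given here, none of the measured steps bears on this change: each of them alters the methoxy pattern of the ring on the carbonyl carbon and leaves the five-membered ring untouched. There is therefore no measured basis for a direction, and compound 4 is expected to sit close to compound 2, with the step of a 1.3-fold higher number from compound 2 to compound 4 (0.10 log units; within the scatter) expected to stay within the scatter. The estimate for compound 4 in this assay is 2000 nM, in a range from 700 nM to 6000 nM.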

Compound 4, half-maximal inhibitory concentration: 1200 nM
The estimate for compound 4 lay 1.7-fold (0.22 log units) above the measured number, and the stated range covers the measured number.
By their numbers in this assay, from the lowest: compounds 4, 2 and 3 (each within the scatter of the next); then compound 1.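

Going by these compounds alone, at this aromatic carbon, next to the ring nitrogen, pyridin-4-yl replaces thiophen-3-yl with a 1.3-fold lower number from compound 2 to compound 4 (0.12 log units; within the scatter) in this assay, the first measured step at this position. A six-membered aromatic ring with a ring nitrogen therefore reads the same here as a five-membered aromatic ring with sulfur. Nothing available bears on the cause of this result. Open, going by these compounds, is whether an amine such as morpholine or a simple chain such as ethyl would be accepted at this position. Also open, on these data alone, is whether the methoxy steps seen with thiophen-3-yl carry over to pyridin-4-yl.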